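Removing the 4-(trifluoromethyl)benzyl group from compound 3

The source may report more compounds than this note shows. Statements on the series, on what has been measured and on what is new or still open speak of the compounds shown alone.

In an ADME assay on microsomes from liver (Rattus norvegicus) for metabolic stability, read by LC-MS, with a stated time of 30 min, tested at 1 uM (a lower number here means that less of the compound is left, a higher number that more of the compound is left), compound 3 `CCNCc1cc(Cl)cc(Nc2nc3ccccc3n2Cc2ccc(C(F)(F)F)cc2)c1O` gives 66%, the highest of the three numbers, ahead of compound 2 `CCNCc1cc(C)cc(Nc2nc3ccccc3n2Cc2ccc(C(F)(F)F)cc2)c1O` at 51% and compound 1 `CC(C)(C)NCc1cc(Cl)cc(Nc2nc3ccccc3n2Cc2ccc(C(F)(F)F)cc2)c1O` at 9%. Compound 4 `CCNCc1cc(Cl)cc(Nc2nc3ccccc3[nH]2)c1O` differs from compound 3 in one place: hydrogen in place of 4-(trifluoromethyl)benzyl on an aromatic nitrogen. Neither measured step touches that nitrogen. Ethyl in place of tert-butyl on an amine nitrogen gave a large step, a number 57 percentage points higher from compound 1 to compound 3 (beyond the scatter), and chloro in place of methyl on an aromatic carbon gave a modest one, a number 15 percentage points higher from compound 2 to compound 3 (beyond the scatter). These steps show that one change can matter here, but they give no direction for this one, so the guess is loose. A modest rise is expected, a number 9 percentage points higher from compound 3 to compound 4 (within the scatter). For compound 4 the estimated value is 75%, with an expected range of 45% to 95%.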

Compound 4, percent of the compound remaining: 98%
For compound 4 the middle estimate is 23 percentage points below the measured one; the measured number lies above the stated range.
By their numbers in this assay, from the lowest: compound 1; then compound 2; then compound 3; then compound 4.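

In this assay, the aromatic nitrogen turns out to be a position that matters: hydrogen in place of 4-(trifluoromethyl)benzyl gives a number 32 percentage points higher from compound 3 to compound 4 (beyond the scatter). Compounds 1, 2 and 3 all carry this benzyl group, so they could not show this. No measurement shown here explains the rise.

As far as these compounds go, it remains open whether the whole benzyl group or only its trifluoromethyl accounts for the step. A plain benzyl or a methyl on this nitrogen could separate the two, and either could land nearer compound 3 or compound 4.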